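This account rests on a few compounds, and the source may have more. Where it says the series, first, only, none or still open, it means among the compounds named here.

Measured compounds in a functional assay on MCF7 cells (Homo sapiens) for antiproliferative activity, read by WST assay, with a stated time of 72 h; a higher number here means a weaker inhibitor, a lower number a stronger inhibitor:
Compound 1, `Cc1noc(-c2cc3ccccc3[nH]2)n1`, gives > 50000 nM in this assay, which is a limit of the assay and not a number.
Compound 2, `COc1ccc2[nH]c(-c3nc(C)no3)cc2c1`, gives 16700 nM in this assay.

Compound 2 thus holds the only number shown; the other value is a limit. One measured step exists, an at least 2.9-fold lower number from compound 1 to compound 2 (0.47 log units; beyond the scatter), a change at the same position, and its size is bounded by the limit of > 50000 nM in this assay, at which 1 of the 2 values shown sits. Compound 3, `Cc1noc(-c2cc3cc(F)ccc3[nH]2)n1`, differs from compound 2 by fluoro in place of methoxy on an aromatic carbon. Among the measured compounds shown here, no measured step covers fluoro at this position, so the only guide is the methoxy step, which ran toward a lower number. Removing methoxy for a smaller group is expected to move the number back toward that of compound 1, by an estimated 1.8-fold higher number from compound 2 to compound 3 (0.25 log units; within the scatter). Compound 3 is therefore estimated at 30000 nM in this assay, within 12000 nM to 80000 nM.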

Compound 3, half-maximal inhibitory concentration: 12400 nM
Compound 3: middle estimate off by 2.4-fold (0.38 log units), on the high side, and the stated range covers the measured number.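

In this assay, among the compounds shown here, fluoro in place of hydrogen on this aromatic carbon gives an at least 4.0-fold lower number from compound 1 to compound 3 (0.60 log units; beyond the scatter), so methoxy is no longer the only group at this position that lowers the number from that of compound 1. The exchange of one group for the other gives a 1.3-fold lower number from compound 2 to compound 3 (0.13 log units; within the scatter), which leaves methoxy and fluoro indistinguishable here, even though they differ in heavy atoms and hydrogen-bond acceptors. Compound 1 stands at a limit of the assay and not at a number, so the true size of the steps away from it stays unknown: the limit of > 50000 nM in this assay, at which 1 of the 3 values shown sits.

The compounds shown leave open whether an amine, a carboxylic acid or a longer alkoxy chain on this carbon would lower the number further. They also leave open whether methoxy or fluoro would act alike on the other carbons of the six-membered aromatic ring.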